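Amine substituent size and in vivo potency in the series

The compounds below may be only part of what the source reports. "The series", "measured", "known", "first", "only" and "open" are said of these compounds alone.

Compound 3 `C=CCN(C)C1CCCC1N(C(=O)CC)c1ccc(Cl)c(Cl)c1` is the higher of the two numbers shown in a functional assay on the whole organism for positive allosteric modulation, with Mus musculus as the target; a lower number here means that less compound is needed, a higher number that more compound is needed for the effect: compound 3 gives 6 mg/kg, while compound 1 `CCC(=O)N(c1ccc(Cl)c(Cl)c1)C1CCCC1N(CC)CC` gives 0.3 mg/kg. Compound 2 `CCCN(CCC)C1CCCC1N(C(=O)CC)c1ccc(Cl)c(Cl)c1` reaches only a limit of this assay, > 50 mg/kg, so the limit of > 50 mg/kg in this assay, at which 1 of the 3 values shown sits, applies to it and not a number. Both measured steps that leave the diethylamino of compound 1 raise the dose: an at least 160-fold higher number from compound 1 to compound 2 (2.22 log units; beyond the scatter), and a 20-fold higher number from compound 1 to compound 3 (1.30 log units; beyond the scatter); between the two larger amines an at least 8.3-fold lower number from compound 2 to compound 3 (0.92 log units; beyond the scatter).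

Compound 4 `CCC(=O)N(c1ccc(Cl)c(Cl)c1)C1CCCC1N(C)Cc1ccccc1` differs from compound 3 by phenyl in place of vinyl on a saturated chain carbon bound to an amine nitrogen. Of the measured steps, those that enlarge the groups on the amine nitrogen bear on it, and both went toward higher doses, the step to compound 2 running into the limit. A higher number than compound 3 is therefore expected in this assay, a 3.3-fold higher number from compound 3 to compound 4 (0.52 log units; beyond the scatter), with some chance that only a limit is returned. The estimate for compound 4 is 20 mg/kg, within 5 mg/kg to 60 mg/kg.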

Compound 4, dose for half-maximal effect: > 50 mg/kg
Compound 4 was reported as a limit (the forecaster's own chance of this, stated with the estimate: 30%); middle value at least 2.5-fold (0.39 log units) from the limit.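

In this assay, the aromatic ring is not tolerated where the vinyl of compound 3 is: phenyl in place of vinyl on a saturated chain carbon bound to an amine nitrogen gives an at least 8.3-fold higher number from compound 3 to compound 4 (0.92 log units; beyond the scatter), and the change from the diethylamino of compound 1 gives an at least 160-fold higher number from compound 1 to compound 4 (2.22 log units; beyond the scatter). Two differently built amines, dipropylamino and benzyl(methyl)amino, now end at a limit, and of the larger amines shown only allyl(methyl)amino keeps a number. Compound 2 and compound 4 both sit at a limit, so the step between them cannot be read: the limit of > 50 mg/kg in this assay, at which 2 of the 4 values shown sit.

Open, on these data alone, is whether dimethylamino or pyrrolidinyl on a saturated ring carbon would stand with compound 1 or with compound 3. Also open, as far as these compounds go, is whether cyclohexylmethyl(methyl)amino would behave like benzyl(methyl)amino, which would separate the aromatic ring from the bulk of the group.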